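A few compounds are considered here, and "the series" means these few. Any claim that something is new, unique, unknown or untested is made for them only; others in the source may bear on it.

Measured compounds:
Compound 1 `CCN(CC)C(=O)[C@@H]1CCCN(S(=O)(=O)c2ccc(S(=O)(=O)N(CC)CC)cc2)C1`: in a functional assay on MIA PaCa-2 cells (Homo sapiens) for inhibition, read by MTT assay, with a stated time of 3 days (a higher number here means a weaker inhibitor, a lower number a stronger inhibitor), compound 1 gives 700 nM.
Compound 2 `CCN(CC)S(=O)(=O)c1ccc(S(=O)(=O)N2CCC[C@@H](C(=O)NC3CN(C(=O)NC(C)(C)C)C3)C2)cc1`: in this assay compound 2 gives 1400 nM.
Compound 3 `CCN(CC)S(=O)(=O)c1ccc(S(=O)(=O)N2CCC[C@@H](C(=O)N3CCN(c4nc(C)no4)CC3)C2)cc1`: in this assay compound 3 gives 200 nM.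

Compound 3 stands lowest of the three numbers: a 3.5-fold lower number from compound 1 to compound 3 (0.54 log units; beyond the scatter) and a 7.0-fold lower number from compound 2 to compound 3 (0.85 log units; beyond the scatter), both beyond the scatter, whereas a 2.0-fold higher number from compound 1 to compound 2 (0.30 log units; within the scatter). All three compounds share the same core and differ only in the group on the carbonyl carbon.

Compound 4 `CCN(CC)S(=O)(=O)c1ccc(S(=O)(=O)N2CCC[C@@H](C(=O)N3CCN(C(=O)OC(C)(C)C)CC3)C2)cc1` differs from compound 3 by tert-butoxycarbonyl in place of 3-methyl-1,2,4-oxadiazol-5-yl on an amine nitrogen in a ring. Among the measured compounds shown here, no measured step alters this same position, so the two steps that lead into compound 3 are the only guide: each shows that exchanging the group attached to the carbonyl carbon shifts the number by a modest amount, in either direction. On that basis a modest change is expected, and a somewhat higher number is judged more likely than a lower one, since compound 3 already holds the lowest number shown. Compound 4 is therefore expected to give about 400 nM in this assay, with a range from 130 nM to 1300 nM. The expected step is a 2.0-fold higher number from compound 3 to compound 4 (0.30 log units; within the scatter).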

Compound 4, half-maximal inhibitory concentration: 10 nM
Compound 4: middle estimate off by 40-fold (1.60 log units), on the high side, outside the stated range (below it).
By their numbers in this assay, from the lowest: compound 4; then compound 3; then compounds 1 and 2 (each within the scatter of the next).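

Compound 4 shows that the group on the amine nitrogen in the six-membered ring can move the number much further than the earlier compounds suggested: tert-butoxycarbonyl in place of 3-methyl-1,2,4-oxadiazol-5-yl gives a 20-fold lower number from compound 3 to compound 4 (1.30 log units; beyond the scatter), the only large step among those shown. It also shows that, on this core, the five-membered aromatic ring is not required at this position for a low number in this assay, as a group with no ring gives the lower value. Nothing shown here explains why this exchange has so large an effect.

Going by these compounds, it remains open which part of tert-butoxycarbonyl matters. An acetyl group, a methoxycarbonyl group or a free ring amine at this nitrogen would help separate the contribution of the carbonyl from that of the tert-butyl end.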